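The source may hold more compounds than are shown below. What is called first, only, known or untested is meant among the compounds shown, and "the series" means these compounds.

In a functional assay on PC-3 cells (Homo sapiens) for antiproliferative activity, read by MTT assay, with a stated time of 96 h (a higher number here means a weaker inhibitor of growth, a lower number a stronger inhibitor of growth), compound 1 `COc1cccc2ccc(Nc3cc(Cl)ccn3)nc12` gives 11900 nM. Compound 2 `COc1ccc(Cl)c2ccc(Nc3cc(Cl)ccn3)nc12` gives > 30000 nM, which is a limit of the assay and not a number. Compound 3 `Oc1ccc(Cl)c2ccc(Nc3cc(Cl)ccn3)nc12` differs from compound 2 by hydrogen in place of methyl on an oxygen on an aromatic ring. Going by the values given here, no measured step covers methoxy to hydroxy. Among the compounds with values here, the only measured step is a chloro change, an at least 2.5-fold higher number from compound 1 to compound 2 (0.40 log units; beyond the scatter), so it is a weak guide to size. On that guide, a modest move toward a lower number is expected in this assay, and a result at the limit remains possible. The expected step is an at least 2.0-fold lower number from compound 2 to compound 3 (0.30 log units; that floor lies within the scatter). For compound 3 the estimated value is 15000 nM, with an expected range of 5000 nM to 30000 nM.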

Compound 3, concentration for 50% growth inhibition: 25500 nM
Compound 3: middle estimate off by 1.7-fold (0.23 log units), on the low side, and the stated range covers the measured number.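

In this assay, methoxy to hydroxy with the chloro group kept gives a measured number rather than a limit: compound 3 gives 25500 nM. Compound 2 gives > 30000 nM, which is a limit of the assay and not a number. The change gives an at least 1.1-fold lower number from compound 2 to compound 3 (0.07 log units; that floor lies within the scatter), so only a floor is known and the true size of the step stays open: the limit of > 30000 nM in this assay, at which 1 of the 3 values shown sits.

On these data alone, whether hydroxy would give a similar step on the core of compound 1, without the chloro group, stays open. Also open, as far as these compounds go, is what an ethyl group on that oxygen, or an amine in place of the hydroxy, would give.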